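This account rests on a few compounds, and the source may have more. Where it says the series, first, only, none or still open, it means among the compounds named here.

Measured compounds in a physicochemical assay for lipophilicity, measured as octanol-water partition; on this read-out higher numbers stand for higher lipophilicity and lower numbers for lower lipophilicity:
compound 1, `CCCC1C(C(=O)OCc2ccccn2)=C(C)NC2=C1C(=O)CCC2`, gives 2.6;
compound 2, `CC1=C(C(=O)OCc2ccccn2)C(c2ccc([N+](=O)[O-])cc2)C2=C(CCCC2=O)N1`, gives 1.88;
compound 3, `CCCC1C(C(=O)OCc2cccnc2)=C(C)NC2=C1C(=O)CCC2`, gives 2.23.

Compound 4, `CC1=C(C(=O)OCc2cccnc2)C(c2ccc([N+](=O)[O-])cc2)C2=C(CCCC2=O)N1`, is not yet measured. It relates to compound 3 as compound 2 relates to compound 1: the change is 4-nitrophenyl in place of propyl on a saturated ring carbon, and the two place lines are the same word for word, so the change is the same one. Between compound 1 and compound 2 that change, (4-nitrophenyl in place of propyl on a saturated ring carbon), made a step of a number 0.72 log units lower from compound 1 to compound 2 (beyond the scatter). The two cores differ by pyridin-3-yl in place of pyridin-2-yl on a saturated chain carbon bound to an oxygen next to a carbonyl group, which gave a number 0.37 log units lower from compound 1 to compound 3 (beyond the scatter). Compound 3 stands second highest of the three values. For compound 4 a step of about a number 0.72 log units lower from compound 3 to compound 4 (beyond the scatter) is expected, because the same change gave a number 0.72 log units lower from compound 1 to compound 2 (beyond the scatter) between compound 1 and compound 2. Compound 4 is therefore estimated at 1.51, likely between 1.2 and 1.85.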

Compound 4, partition coefficient: 1.51
Estimate against measurement, compound 4: no gap at the digits printed; measured number inside the range.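

In this assay, 4-nitrophenyl in place of propyl on a saturated ring carbon gave a number 0.72 log units lower from compound 3 to compound 4 (beyond the scatter) and so matched a number 0.72 log units lower from compound 1 to compound 2 (beyond the scatter); likewise, pyridin-3-yl in place of pyridin-2-yl gave a number 0.37 log units lower from compound 2 to compound 4 (beyond the scatter) and so matched a number 0.37 log units lower from compound 1 to compound 3 (beyond the scatter). Across these four compounds, each change therefore carried from one core to the other with its size intact. That is one pair of cores and does not make a rule for other cores, and nothing available explains why the steps agree.

The compounds shown leave open whether the step would hold for a plain phenyl or a chain longer than propyl on that carbon. They also leave open how a pyridin-4-yl would behave in place of the pyridin-2-yl.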